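The source may hold more compounds than are shown below. What is called first, only, known or untested is meant among the compounds shown, and "the series" means these compounds.

Measured so far in this assay, an ADME assay on microsomes from liver (Homo sapiens) for metabolic stability; a higher number here means faster removal of the compound, a lower number slower removal:
compound 1, `CCOC(=O)N1C[C@@H]2C[C@H]1CN2c1nc(-c2cnc(N)c(OC(F)F)n2)cc(N2CC3CC2C3)n1`, gives 11.1 mL/min/kg
compound 2, `Nc1ncc(-c2cc(C3CC3)nc(N3C[C@@H]4C[C@H]3CO4)n2)nc1OC(F)F`, gives 11 mL/min/kg
compound 3, `CCOC(=O)N1C[C@@H]2C[C@H]1CN2c1nc(-c2cnc(N)c(OC(F)F)n2)cc(C2CC2)n1`, gives 12.6 mL/min/kg

All three numbers sit within the scatter of one another; compound 2 has the lowest of the three, but its gaps to compound 1 and to compound 3 are within the scatter, so no order is claimed among them. Within the data shown here, the one counted step, a 1.1-fold lower number from compound 3 to compound 1 (0.06 log units; within the scatter), comes from a group of 6 heavy atoms (5 carbon, 1 nitrogen; one four-membered non-aromatic ring of carbon only, one five-membered non-aromatic ring with 1 hetero atom) in place of a group of 3 heavy atoms (3 carbon; one three-membered non-aromatic ring of carbon only), on an aromatic carbon.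

Compound 4, `Nc1ncc(-c2cc(N3CC4CC3C4)nc(N3C[C@@H]4C[C@H]3CO4)n2)nc1OC(F)F`, is not yet measured in this assay. It arises from compound 2 by a group of 6 heavy atoms (5 carbon, 1 nitrogen; one four-membered non-aromatic ring of carbon only, one five-membered non-aromatic ring with 1 hetero atom) in place of a group of 3 heavy atoms (3 carbon; one three-membered non-aromatic ring of carbon only), on an aromatic carbon. This is the same kind of change as that from compound 3 to compound 1, though the surroundings of the place differ between compound 2 and compound 3. How the core of compound 2 differs from the core of compound 3 is not broken down here.

For compound 4 the step is expected to be a 1.0-fold lower number from compound 2 to compound 4 (0.02 log units; within the scatter), resting on the earlier step of a 1.1-fold lower number from compound 3 to compound 1 (0.06 log units; within the scatter), which stayed within the scatter. Compound 4 is therefore expected to give 10.5 mL/min/kg, with a range from 5.5 mL/min/kg to 20 mL/min/kg.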

Compound 4, clearance: 9.3 mL/min/kg
For compound 4 the middle estimate is 1.1-fold (0.05 log units) above the measured one, and the stated range covers the measured number.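

In this assay, putting the group of 6 heavy atoms in place of cyclopropyl on an aromatic carbon gives a 1.2-fold lower number from compound 2 to compound 4 (0.07 log units; within the scatter), which lies within the scatter on this core too. Set beside the earlier case, the two steps agree: the same change on two cores in this assay, a 1.1-fold lower number (0.06 log units; within the scatter) from compound 3 to compound 1 and a 1.2-fold lower number (0.07 log units; within the scatter) from compound 2 to compound 4, 1.0-fold (0.02 log units) apart, within the scatter of two such steps. This shows that the change has stayed within the scatter on both cores shown, but two pairs give no rule for a further core, and with no step beyond the scatter in either pair they do not test whether a larger effect would carry from one core to another.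

The compounds shown leave open how the number responds to other groups on this aromatic carbon, such as an open-chain amine, a carboxylic acid or a longer alkyl chain, and whether any of these would give a step beyond the scatter. They also leave open whether the swap of cyclopropyl for the group of 6 heavy atoms behaves the same way on a core other than those of compound 2 and compound 3.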